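Swapping Methoxy for Bromo on Two Hydrazide Cores

The compounds below may be only part of what the source reports. "The series", "measured", "known", "first", "only" and "open" are said of these compounds alone.

Compound 1, `COc1ccc(C(=O)NNc2nc3ccccc3nc2Cc2ccccc2)cc1`, gives 86 nM in an assay for inhibition of Amine oxidase [flavin-containing] A (Bos taurus), read by fluorescence, with a stated time of 60 min; on this read-out lower numbers stand for stronger inhibition and higher numbers for weaker inhibition.
Compound 2, `O=C(NNc1nc2ccccc2nc1Cc1ccccc1)c1ccc(Br)cc1`, gives 74 nM in this assay.
Compound 3, `COc1ccc(/C=N/NC(=O)Cn2c(=O)c(Cc3ccccc3)nc3ccccc32)cc1`, gives 6.6 nM in this assay.

Compounds 1 and 2 share one core and differ in a single place: bromo in place of methoxy on an aromatic carbon. That change produced a 1.2-fold lower number from compound 1 to compound 2 (0.07 log units; within the scatter), so the two compounds behave alike. Compound 3 is built on a different core; the difference between the two cores is not broken down here. Its number in this assay is the lowest of the three, and its distance from both compound 1 and compound 2 lies beyond the scatter.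

Compound 4, `O=C(Cn1c(=O)c(Cc2ccccc2)nc2ccccc21)N/N=C/c1ccc(Br)cc1`, has not yet been measured. It differs from compound 3 by bromo in place of methoxy on an aromatic carbon, the same change that separates compound 1 from compound 2, made at the same place on the ring. The same change in the first pair gave only a 1.2-fold lower number from compound 1 to compound 2 (0.07 log units; within the scatter). The expected step in this assay is therefore small, a 1.1-fold lower number from compound 3 to compound 4 (0.04 log units; within the scatter), and would most likely stay within the scatter. Compound 4 is therefore estimated to give about 6 nM in this assay, with a likely range from 2.5 nM to 15 nM.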

Compound 4, half-maximal inhibitory concentration: 22 nM
Compound 4: the middle estimate sits 3.7-fold (0.56 log units) below what was measured; measured number above the stated range.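

In this assay, bromo in place of methoxy gave a 3.3-fold higher number from compound 3 to compound 4 (0.52 log units; beyond the scatter), whereas on the core of compound 1 the same change gave a 1.2-fold lower number from compound 1 to compound 2 (0.07 log units; within the scatter). Set side by side, the two steps do not match, so the small effect seen on the first core did not carry over to the second: the same change on two cores in this assay, a 1.2-fold lower number (0.07 log units; within the scatter) from compound 1 to compound 2 and a 3.3-fold higher number (0.52 log units; beyond the scatter) from compound 3 to compound 4, 3.9-fold (0.59 log units) apart, beyond the scatter of two such steps. This shows that, in this series, a step measured on one core cannot be assumed to hold on the other, but it does not show why the steps differ, which part of the cores matters, or what the change would do on any further core.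

The compounds shown carry only methoxy or bromo on this aromatic carbon, so it remains open whether chloro, methyl, an amine or a plain hydrogen there would follow the same trend on each core. Going by these compounds, it also remains open whether the gap between the two steps would appear with such groups at all.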